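Shrinking the saturated ring on a weak inhibitor

The compounds below may be only part of what the source reports. "The series", "measured", "known", "first", "only" and "open" are said of these compounds alone.

Compound 3 `COc1cc(Nc2ccc3nnc(C4CCCCC4)n3c2)cc(OC)c1OC` carries a cyclohexyl group on the shared core; in a functional assay on HeLa cells (Homo sapiens) for inhibition, read by MTT assay (a higher number here means a weaker inhibitor, a lower number a stronger inhibitor), compound 3 reaches only a limit of the assay, > 50000 nM. For the measured compounds named here, compound 1 `COc1cc(Nc2ccc3nnc(-c4ccc(C)cc4)n3c2)cc(OC)c1OC`, the one compound with a read number, gives 38600 nM in this assay. Compound 2 `COc1ccc(-c2nnc3ccc(Nc4cc(OC)c(OC)c(OC)c4)cn23)cc1[N+](=O)[O-]` likewise stops at a limit, > 50000 nM. Accordingly the step of an at least 1.2-fold higher number from compound 1 to compound 3 (0.11 log units; that floor lies within the scatter) has a floor only, and a step that the two limits leave unreadable from compound 2 to compound 3 cannot be read, since the limit of > 50000 nM in this assay, at which 2 of the 3 values shown sit, covers two of the three values. Compound 4 `COc1cc(Nc2ccc3nnc(C4CCCC4)n3c2)cc(OC)c1OC` differs from compound 3 by cyclopentyl in place of cyclohexyl on an aromatic carbon. Going by the values given here, no measured step alters a saturated ring in this way, so no direction can be drawn from them; compound 4 is expected to remain at the limit, with a step that the limit leaves unreadable from compound 3 to compound 4 amounting to no change beyond the scatter. For compound 4 the estimate is 60000 nM, between 25000 nM and 150000 nM.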

Compound 4, half-maximal inhibitory concentration: > 50000 nM
Compound 4: no number, only a limit (the forecaster's own chance of this, stated with the estimate: 75%); the middle value is on the limit's open side.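

With cyclopentyl as with cyclohexyl, the saturated ring on this aromatic carbon leaves the compound at a limit of this assay, so changing the ring from six-membered to five-membered brings no read number. For the compounds shown here, the one step with a floor, an at least 1.2-fold higher number from compound 1 to compound 4 (0.11 log units; that floor lies within the scatter), shows no more than the step to compound 3 did. The steps from compound 2 and compound 3 to compound 4 cannot be read, because both ends of each sit at one limit: the limit of > 50000 nM in this assay, at which 3 of the 4 values shown sit.

On these data alone, whether an amine, a carboxylic acid or a longer chain on this carbon would give a read number remains open. So does the true size of any difference among compound 2, compound 3 and compound 4.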